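The compounds below may be only part of what the source reports. "The series", "measured", "known", "first", "only" and "open" are said of these compounds alone.

Two compounds share a core and differ only in the group carried on an aromatic carbon of its fused ring system. Compound 1 `CN1CCN(c2ccn3c(-c4ccc(NC(=O)c5ccc([N+](=O)[O-])o5)cc4)cnc3c2)CC1` gives in a functional assay on AGS cells (Homo sapiens) for antiproliferative activity, read by CCK-8 assay, with a stated time of 72 h (on this read-out lower numbers stand for stronger inhibition and higher numbers for weaker inhibition), a value of 2340 nM, the highest of the two numbers recorded; its nearest neighbour is compound 2 `O=C(Nc1ccc(-c2cnc3cc(N4CCCC4)ccn23)cc1)c1ccc([N+](=O)[O-])o1`, which in this assay gives 1240 nM. For the measured compounds named here, the single measured step, a 1.9-fold lower number from compound 1 to compound 2 (0.28 log units; within the scatter), stays within the scatter of repeated measurements, so the two values cannot be ordered.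

Compound 3 `COc1ccn2c(-c3ccc(NC(=O)c4ccc([N+](=O)[O-])o4)cc3)cnc2c1` has not yet been measured. Relative to compound 1 it shows (methoxy in place of 4-methylpiperazin-1-yl on an aromatic carbon). Going by the values given here, the only step that bears on this change is the one from compound 1 to compound 2, where a different group replaced the same 4-methylpiperazin-1-yl at the same place and produced a 1.9-fold lower number from compound 1 to compound 2 (0.28 log units; within the scatter). On that evidence a step beyond the scatter is not expected in this assay, and no direction can be argued from the data. Compound 3 is therefore expected to land near compound 1, at an estimated 2000 nM with a range from 700 nM to 6000 nM, an expected step of a 1.2-fold lower number from compound 1 to compound 3 (0.07 log units; within the scatter).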

Compound 3, half-maximal inhibitory concentration: 720 nM
The estimate for compound 3 lay 2.8-fold (0.44 log units) above the measured number, within the range that was stated.
By their numbers in this assay, from the lowest: compounds 3, 2 and 1 (each within the scatter of the next, the first and the last beyond it).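

For the compounds shown here, at the aromatic carbon opposite the ring nitrogen, the change to methoxy in this assay gives a 3.3-fold lower number from compound 1 to compound 3 (0.51 log units; beyond the scatter), the first step at this place to clear the scatter, so the group carried here can shift the number measurably and need not contain a ring. Against pyrrolidin-1-yl, the same group gives a 1.7-fold lower number from compound 2 to compound 3 (0.24 log units; within the scatter), which lies within the scatter, so only the methoxy and 4-methylpiperazin-1-yl compounds are separated, while compound 2 cannot be ordered against either of them. No measurement shown here offers an explanation for the step from the 4-methylpiperazin-1-yl group to methoxy.

Going by these compounds, whether ethoxy, a hydroxyl group or an open-chain dimethylamino group at this carbon would fall with methoxy or with 4-methylpiperazin-1-yl remains open. A morpholine ring would also help to show whether the separation follows the ring, the number of heavy atoms or the second ring nitrogen, since the three groups shown differ in more than one of these at once.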